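Replacing the Amine Tail: From Compound 1 to Compound 4

A few compounds are considered here, and "the series" means these few. Any claim that something is new, unique, unknown or untested is made for them only; others in the source may bear on it.

Compound 1, `CN(C)CCCOc1ccccc1/C=C/c1ccccc1`: 14.2%
Compound 2, `CN(C)CCCCOc1ccccc1/C=C/c1ccccc1Cl`: 14.3%
Compound 3, `COc1ccccc1/C=C/c1ccccc1OCCCCN(C)C`: 0%

Of the compounds shown here, three have been tested in a functional assay on the whole organism with Mus musculus as the target, in the maximal electroshock model, at a dose of 50 mg/kg by the oral route; on this read-out lower numbers stand for less inhibition and higher numbers for more inhibition at the one dose given (going by the name of the read-out). Compound 1 stands second highest of the three numbers. Its nearest neighbour is compound 2, whose number is within the usual scatter of that of compound 1, so the two cannot be told apart. Compound 3 lies furthest away, beyond the scatter, with the lowest number of the set.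

For the measured compounds named here, the one measured step that differs in a single place is a number 14.3 percentage points lower from compound 2 to compound 3 (beyond the scatter). It concerns a group on an aromatic carbon, not the amine at the end of the chain.

Compound 4, `OC1CCN(CCCCOc2ccccc2/C=C/c2ccccc2)CC1`, has not yet been measured in this assay. It differs from compound 1 in one place: (4-hydroxypiperidin-1-yl)methyl in place of dimethylamino on a saturated chain carbon, three bonds along the chain from an oxygen on an aromatic ring. Going by the values given here, no measured step touches the amine end of the chain, so nothing among the tested compounds shows how such a change plays out here. The change is therefore expected to give no step beyond the scatter, a number 2.2 percentage points lower from compound 1 to compound 4 (within the scatter). Compound 4 is estimated at 12%, within the range 0% to 30%.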

Compound 4, a percentage reported as inhibition, in the whole organism at one dose (the size of the read-out at that dose, not a potency): 0%
Compound 4: middle estimate off by 12 percentage points, on the high side, within the range that was stated.
By their numbers in this assay, from the lowest: compounds 3 and 4 (each within the scatter of the next); then compounds 1 and 2 (each within the scatter of the next).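

For the compounds shown here, the change from dimethylamino to (4-hydroxypiperidin-1-yl)methyl is the first measured change at the amine end of the chain, and in this assay it gives a number 14.2 percentage points lower from compound 1 to compound 4 (beyond the scatter) on the same shared core. The earlier step beyond the scatter concerned a group on an aromatic carbon, so this result adds that a change at the amine end can also lower the number at the one dose given. No measured evidence here explains why the number falls with this change.

The change alters several things at once: 3 heavy atoms with no ring give way to 8 heavy atoms with a six-membered non-aromatic ring and a hydrogen-bond donor, and the compounds shown do not separate these features. A plain piperidine without the hydroxyl, a morpholine or a diethylamino group at the same place on the chain could help show whether the ring, the hydroxyl or simply the larger amine goes with the lower number.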